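This account rests on a few compounds, and the source may have more. Where it says the series, first, only, none or still open, it means among the compounds named here.

For the measured compounds named here, in a functional assay on K562 cells (Homo sapiens) for antiproliferative activity, read by MTT assay, with a stated time of 24 h (a higher number here means a weaker inhibitor, a lower number a stronger inhibitor), compound 3 `COc1ccc(C(=O)/C=C/c2cccc([N+](=O)[O-])c2)c2c1C=CC(C)(C)O2` gives 5870 nM, the only actual number so far. Compound 1 `COc1cccc(/C=C/C(=O)c2ccc(OC)c3c2OC(C)(C)C=C3)c1` reads > 10000 nM, which is a limit of the assay and not a number. Compound 2 `COc1ccc(/C=C/C(=O)c2ccc(OC)c3c2OC(C)(C)C=C3)c(F)c1` reads > 10000 nM, again a limit. Compound 4 `COc1ccc(C(=O)/C=C/c2ccco2)c2c1C=CC(C)(C)O2` carries furan-2-yl in place of 3-nitrophenyl on a double-bonded chain carbon bound to a double-bonded chain carbon. The closest measured change, at that same place, is an at least 1.7-fold lower number from compound 2 to compound 3 (0.23 log units; that floor lies within the scatter). The other one that bears on it is an at least 1.7-fold lower number from compound 1 to compound 3 (0.23 log units; that floor lies within the scatter). Neither shows a firm size, so they are only a weak guide. In this assay, the expected 1.5-fold higher number from compound 3 to compound 4 (0.19 log units; within the scatter) is a modest rise, since compound 4 gives up the nitro group. Compound 4 is estimated at 9000 nM, with an expected range from 3500 nM to 20000 nM.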

Compound 4, half-maximal inhibitory concentration: > 10000 nM
Compound 4 ended at the assay's limit (the forecaster's own chance of this, stated with the estimate: 45%); middle value at least 1.1-fold (0.04 log units) from the limit.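

In this assay, furan-2-yl in place of 3-nitrophenyl gives an at least 1.7-fold higher number from compound 3 to compound 4 (0.23 log units; that floor lies within the scatter), so a five-membered ring at this place shows no firm change from compound 3. For the compounds shown here, compound 4 reads as a limit, not a number, and compound 3 remains the only compound with an actual number: the limit of > 10000 nM in this assay, at which 3 of the 4 values shown sit. The steps to compound 4 from compound 1 and from compound 2 cannot be read, since both ends are limits.

Going by these compounds, whether a firm difference exists between 3-nitrophenyl and furan-2-yl stays open. So does whether a phenyl ring carrying an amine or a carboxylic acid at this place would give a clearly lower number.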